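The source may hold more compounds than are shown below. What is called first, only, known or untested is meant among the compounds shown, and "the series" means these compounds.

The measured compounds:

compound 1 `COc1ccc(-n2ccc(=O)c(C(=O)Nc3ccc(Oc4ccnc5[nH]ccc45)cc3)n2)cc1`: 50800 nM
compound 2 `COc1ccc(-n2ccc(=O)c(C(=O)Nc3ccc(Oc4ccnc5c4ccn5C)cc3)n2)cc1`: > 60000 nM
compound 3 `Cc1cc(=O)n(-c2ccccc2OC(F)(F)F)nc1C(=O)Nc1ccc(Oc2ncnc3[nH]ccc23)cc1`: 22800 nM

All three were tested in a functional assay on HepG2 cells (Homo sapiens) for cytotoxicity, read by MTT assay, with a stated time of 72 h; a higher number here means a weaker inhibitor, a lower number a stronger inhibitor. Compound 1 gives 50800 nM in this assay. For compound 2 the reported value of > 60000 nM is a limit of the assay rather than a number; it sits at the limit of > 60000 nM in this assay, at which 1 of the 3 values shown sits. The change from compound 1 to compound 2 is methyl in place of hydrogen on an aromatic nitrogen, and it produced an at least 1.1-fold higher number from compound 1 to compound 2 (0.07 log units; that floor lies within the scatter). Compound 3 gives 22800 nM, the lowest number of the two numbers here. The difference between the core of compound 1 and the core of compound 3 is not broken down here.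

Compound 4 `Cc1cc(=O)n(-c2ccccc2OC(F)(F)F)nc1C(=O)Nc1ccc(Oc2ncnc3c2ccn3C)cc1` has not been measured. It differs from compound 3 by methyl in place of hydrogen on an aromatic nitrogen, the same change as that from compound 1 to compound 2. Because an at least 1.1-fold higher number from compound 1 to compound 2 (0.07 log units; that floor lies within the scatter) was at least a small rise, a comparable step is expected here, namely a 1.6-fold higher number from compound 3 to compound 4 (0.20 log units; within the scatter). Compound 4 is therefore estimated at 36000 nM in this assay, with a likely span from 15000 nM to 80000 nM.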

Compound 4, half-maximal inhibitory concentration: > 60000 nM
Compound 4 was reported as a limit; the forecaster's own chance of this, stated with the estimate: 25%; middle value at least 1.6-fold (0.22 log units) from the limit.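

On the core of compound 3, methyl in place of hydrogen on an aromatic nitrogen gave an at least 2.6-fold higher number from compound 3 to compound 4 (0.42 log units; beyond the scatter) in this assay, a step that can be told apart from the usual scatter even as a floor. The results for compound 2 and compound 4 are both limits of the assay and not numbers, so each step is known only as a floor, and the true size of neither can be read: the limit of > 60000 nM in this assay, at which 2 of the 4 values shown sit. The change can therefore be said neither to carry over from one core to the other with the same size nor to differ in size between them: the same change on two cores in this assay, an at least 1.1-fold higher number (0.07 log units; that floor lies within the scatter) from compound 1 to compound 2 and an at least 2.6-fold higher number (0.42 log units; beyond the scatter) from compound 3 to compound 4; the limit leaves it open whether they differ.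

The compounds shown leave open how an ethyl group, a longer chain or a chain ending in an amine on that aromatic nitrogen would read in this assay. They also leave open how large the step from hydrogen to methyl really is on either core, since both methyl compounds end at the limit.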